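Ester series on the shared core: triazole nitrogen substituent

The source may hold more compounds than are shown below. What is called first, only, known or untested is meant among the compounds shown, and "the series" means these compounds.

Among the compounds with values here, compound 1 `CCOC(=O)C1=Cc2ccccc2OC1(OCc1cn(CC(=O)Nc2ccc(OC)cc2)nn1)C(F)(F)F` is the one member with a number in a functional assay on HeLa cells (Homo sapiens) for inhibition, read by MTT assay, with a stated time of 24 h; a higher number here means a weaker inhibitor, a lower number a stronger inhibitor: compound 1 gives 31900 nM. The other two members of the set are acids with a different five-membered ring. Compound 2 `O=C(O)C1=Cc2ccccc2OC1(OCc1cc(-c2ccc([N+](=O)[O-])cc2)no1)C(F)(F)F` is reported in this assay only as a limit, > 150000 nM. Compound 3 `O=C(O)C1=Cc2ccccc2OC1(OCc1cc(-c2ccc(F)cc2F)no1)C(F)(F)F` likewise reaches only the limit of this assay, > 150000 nM. Within the data shown here, the single measured step, a step that the two limits leave unreadable from compound 2 to compound 3, therefore says nothing about size; both of its ends sit at the limit of > 150000 nM in this assay, at which 2 of the 3 values shown sit. Compound 4 `CCOC(=O)C1=Cc2ccccc2OC1(OCc1cn(-c2ccc([N+](=O)[O-])cc2)nn1)C(F)(F)F` differs from compound 1 in one place: 4-nitrophenyl in place of ((4-methoxyphenyl)carbamoyl)methyl on an aromatic nitrogen. Among the measured compounds shown here, no measured step touches this position or this kind of exchange, and the acid pair carries a different ring and a different acid head, so it cannot be read across. The expectation for this assay rests on compound 1 alone and on the absence of any readable step, so no movement beyond the scatter is assumed. Compound 4 is therefore expected to show a step of a 1.3-fold higher number from compound 1 to compound 4 (0.10 log units; within the scatter) from compound 1. Compound 4 is estimated at 40000 nM in this assay, with a range from 10000 nM to 150000 nM.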

Compound 4, half-maximal inhibitory concentration: > 150000 nM
Compound 4 ended at the assay's limit (the forecaster's own chance of this, stated with the estimate: 25%); middle value at least 3.7-fold (0.57 log units) away from the limit.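

In this assay, within the data shown here, the substituent on the aromatic nitrogen gives the first readable step in the set: with 4-nitrophenyl in place of ((4-methoxyphenyl)carbamoyl)methyl there is an at least 4.7-fold higher number from compound 1 to compound 4 (0.67 log units; beyond the scatter) and the number of compound 1 is not kept. This exchange changes several features together, since the amide hydrogen and its carbonyl leave with the 4-methoxyphenyl group, and the substituent goes from 12 heavy atoms to 9 and from 1 hydrogen-bond donor to 0. Compound 4 gives a limit and not a number, so the size of the step has only a lower bound, and the shown set now sits mostly at that limit: the limit of > 150000 nM in this assay, at which 3 of the 4 values shown sit.

On these data alone, compounds 1 and 4 alone cannot separate the parts of the leaving group, so it stays open whether the amide, the methylene link or the 4-methoxy group on the phenyl ring carries the step. Also open, as far as these compounds go, is how an amine or a longer chain on the aromatic nitrogen would read in this assay, and whether any such group would give a number below the limit.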